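A few compounds are considered here, and "the series" means these few. Any claim that something is new, unique, unknown or untested is made for them only; others in the source may bear on it.

Within the data shown here, compound 1 `CCN(CC)C(=O)CN(c1cccc(N(C)C)c1C#N)S(=O)(=O)c1ccc(OC)c(OC)c1` holds the lower of the two numbers measured so far: in a functional assay on CHO cells for inhibition of Orexin receptor type 2 (Homo sapiens), read by FLIPR and calcium flux (on this read-out lower numbers stand for stronger inhibition and higher numbers for weaker inhibition), compound 1 gives 110 nM. Compound 2 `CCN(CC)C(=O)CN(c1cc(N2CCCC2)ccc1Cl)S(=O)(=O)c1ccc(OC)c(OC)c1` in this assay gives 1610 nM, a gap from compound 1 that lies beyond the scatter. Compound 3 `CCN(CC)C(=O)CN(c1cc(Cl)ccc1N(C)C)S(=O)(=O)c1ccc(OC)c(OC)c1` is compound 1 with 5-chloro-2-(dimethylamino)phenyl in place of 2-cyano-3-(dimethylamino)phenyl on a sulfonamide nitrogen. Among the measured compounds shown here, no measured pair shows this change on its own, so the expectation rests on the two values in hand. A move toward weaker inhibition in this assay is expected, of the size a 4.5-fold higher number from compound 1 to compound 3 (0.66 log units; beyond the scatter). Compound 3 is estimated at 500 nM in this assay, with a range from 150 nM to 2000 nM.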

Compound 3, half-maximal inhibitory concentration: 60 nM
Estimate against measurement, compound 3: 8.3-fold (0.92 log units) above; the whole stated range lies above it.
By their numbers in this assay, from the lowest: compounds 3 and 1 (each within the scatter of the next); then compound 2.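

In this assay, 5-chloro-2-(dimethylamino)phenyl in place of 2-cyano-3-(dimethylamino)phenyl on a sulfonamide nitrogen gives a 1.8-fold lower number from compound 1 to compound 3 (0.26 log units; within the scatter) and, with the nitrile gone and a chlorine present, the two compounds cannot be told apart. This position therefore accepts an aryl group without the nitrile while inhibition remains in the same range. Nothing available accounts for this result.

The chlorine and the changed place of the dimethylamino group arrive together, so their separate contributions remain unresolved. As far as these compounds go, how a morpholine in place of the dimethylamino group would read also remains open.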